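The compounds below may be only part of what the source reports. "The series", "measured", "known", "first", "only" and "open" are said of these compounds alone.

Numbers below come from an assay on isolated protein for inhibition of Rho-associated protein kinase 2 (Homo sapiens), read by scintillation counting, radiometric assay and 33P incorporation, with a stated time of 40 min, in the presence of a further agent that is not named here; a higher number here means a weaker inhibitor, a lower number a stronger inhibitor.

compound 1 `CN(C)c1ccc(C(=O)Nc2cccc(NC(=O)COc3ccc4c(c3)CCC(=O)N4)c2)cc1`: 9970 nM
compound 2 `COc1ccc(OCC(=O)Nc2cccc(NC(=O)c3ccc(N(C)C)cc3)c2)cc1F`: 652 nM
compound 3 `CCCc1ccc(C(=O)Nc2cccc(NC(=O)COc3ccc4c(=O)ccoc4c3)c2)cc1`: 14 nM

Compound 3 stands lowest of the three in this assay; compound 2 is the nearest, compound 1 the furthest, both well beyond the scatter.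

Compound 4 `O=C(COc1ccc2c(=O)ccoc2c1)Nc1cccc(NC(=O)c2ccc([N+](=O)[O-])cc2)c1` differs from compound 3 in one place: nitro in place of propyl on an aromatic carbon. Among the compounds with values here, the only measured single step, a 15-fold lower number from compound 1 to compound 2 (1.18 log units; beyond the scatter), concerns the aryl on the ether side, not the benzamide phenyl, so it does not bear on this change; compounds 1 and 3 differ in two places at once and give no clean reading either. Expectation rests on compound 3 alone, with a wide range and uncertain direction: a step of a 2.9-fold higher number from compound 3 to compound 4 (0.46 log units; beyond the scatter) is expected. Compound 4 is estimated at 40 nM, between 8 nM and 300 nM.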

Compound 4, half-maximal inhibitory concentration: 15 nM
The estimate for compound 4 lay 2.7-fold (0.43 log units) above the measured number, and the stated range covers the measured number.
By their numbers in this assay, from the lowest: compounds 3 and 4 (each within the scatter of the next); then compound 2; then compound 1.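

In this assay the change from 4-propylphenyl to 4-nitrophenyl gives a 1.1-fold higher number from compound 3 to compound 4 (0.03 log units; within the scatter) and so shows that this position, on an aromatic carbon para to a large group, accepts nitro in place of propyl, even though nitro brings 2 hydrogen-bond acceptors and propyl brings 0. Nothing available explains why the two groups read alike.

From the compounds shown here alone, whether an amine, a carboxylic acid or a longer chain on this carbon would also stay close to compound 3 remains open. Going by these compounds, whether nitro reads the same alongside the ether-side groups of compound 1 and compound 2 also remains open.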